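Swapping the head group of a thiourea TRPV1 ligand

The source may report more compounds than this note shows. Statements on the series, on what has been measured and on what is new or still open speak of the compounds shown alone.

Measured compounds:
Compound 1 `COc1cc(CNC(=S)NCC(COC(=O)C(C)(C)C)Cc2ccc(C)c(C)c2)ccc1O` gives 17.4 nM in an assay on isolated protein for binding affinity to transient receptor potential cation channel subfamily V member 1 (Rattus norvegicus); a lower number here means a stronger inhibitor, a higher number a weaker inhibitor.
Compound 2 `CC(=O)Nc1ccc(C/N=C(\S)NCC(COC(=O)C(C)(C)C)Cc2ccc(C)c(C)c2)cc1` gives 1700 nM in this assay.
Compound 3 `COc1cc(C/N=C(\S)NCC(COC(=O)C(C)(C)C)Cc2ccc(C)c(C)c2)ccc1NS(C)(=O)=O` gives 49 nM in this assay.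

Among these three, compound 1 has the lowest number, and its steps to compound 3 and to compound 2 are both beyond the usual scatter, so compound 1 is the strongest binder of the set. Compound 3, which carries a methanesulfonamido group on its head ring, sits closer to compound 1 than compound 2 does, and compound 2 lies far away from both.

Compound 4 `Cc1ccc(CC(CNC(=S)NCc2ccc(NS(C)(=O)=O)c(F)c2)COC(=O)C(C)(C)C)cc1C` has not yet been measured. It differs from compound 1 in one place: 3-fluoro-4-(methanesulfonamido)phenyl in place of 4-hydroxy-3-methoxyphenyl on a saturated chain carbon bound to an amide-type nitrogen. Going by the values given here, the only guide to this change is compound 3, whose methanesulfonamido-bearing head gave 49 nM, a higher number than that of compound 1. On that basis compound 4 is expected to land at a somewhat higher number than compound 1, with a step from compound 1 to compound 4 of about a 1.7-fold higher number from compound 1 to compound 4 (0.24 log units; within the scatter), and is estimated at 30 nM with a range from 8 nM to 120 nM.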

Compound 4, inhibition constant: 54 nM
The estimate for compound 4 lay 1.8-fold (0.26 log units) below the measured number, and the stated range covers the measured number.
By their numbers in this assay, from the lowest: compound 1; then compounds 3 and 4 (each within the scatter of the next); then compound 2.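

In this assay, putting 3-fluoro-4-(methanesulfonamido)phenyl in place of 4-hydroxy-3-methoxyphenyl gives a 3.1-fold higher number from compound 1 to compound 4 (0.49 log units; beyond the scatter), a modest loss of binding. Going by these compounds alone, this is the first step at this position that changes only the head group, and it shows that 4-hydroxy-3-methoxyphenyl is not the only head that keeps binding strong: compound 4 gives 54 nM, whereas compound 2 gives 1700 nM. Nothing measured here explains the difference between the two heads.

Compound 3 and compound 4 lie within the scatter of each other, so these numbers do not separate the methoxy group from the fluorine on the methanesulfonamido-bearing ring. From the compounds shown here alone, it remains open how a chlorine in place of that fluorine, or a free amine in place of the methanesulfonamido group, would change binding.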